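Aryl substituent change on the shared core: methylsulfanyl to hydroxy

The source may hold more compounds than are shown below. What is called first, only, known or untested is meant among the compounds shown, and "the series" means these compounds.

Compound 1 `O=C1NCCN(c2cccc(F)c2)N1` gives 19000 nM in an assay on RBL-1 cells for inhibition of Polyunsaturated fatty acid 5-lipoxygenase (Rattus norvegicus); on this read-out lower numbers stand for stronger inhibition and higher numbers for weaker inhibition. Compound 2 `CSc1cccc(N2CCNC(=O)N2)c1`, carrying the same core, gives 14000 nM in this assay. For the measured compounds named here, the only measured step, a 1.4-fold lower number from compound 1 to compound 2 (0.13 log units; within the scatter), does not separate the two compounds; compound 2 and compound 1 sit within the scatter of each other, and compound 2 has no other neighbour on these numbers.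

Compound 3 `O=C1NCCN(c2cccc(O)c2)N1` is the next member: hydroxy in place of methylsulfanyl on an aromatic carbon. Going by the values given here, no measured step touches a hydroxy group, so the only comparison that bears on it is the one from compound 1 to compound 2, where fluoro gave way to methylsulfanyl at the same aromatic carbon without a change beyond the scatter. On that basis the step from compound 2 to compound 3 in this assay is expected to stay within the scatter too, a 1.1-fold higher number from compound 2 to compound 3 (0.03 log units; within the scatter), with no direction preferred. For compound 3 the value in this assay is therefore estimated at 15000 nM, with a range from 5000 nM to 45000 nM.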

Compound 3, half-maximal inhibitory concentration: 32000 nM
Estimate against measurement, compound 3: 2.1-fold (0.33 log units) below, and the stated range covers the measured number.
By their numbers in this assay, from the lowest: compounds 2, 1 and 3 (each within the scatter of the next, the first and the last beyond it).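

For the compounds shown here, at this aromatic carbon, meta to a group of 7 heavy atoms, the substituent now separates two compounds for the first time: the change from methylsulfanyl to hydroxy gives a 2.3-fold higher number from compound 2 to compound 3 (0.36 log units; beyond the scatter) in this assay and is a modest step beyond the scatter, whereas the earlier change from fluoro to methylsulfanyl stayed within it. Hydroxy in place of fluoro gives a 1.7-fold higher number from compound 1 to compound 3 (0.23 log units; within the scatter) and does not separate those two compounds, so the only readable difference at this position lies between methylsulfanyl and hydroxy, with fluoro not distinguished from either. The full spread of the three compounds is this single modest step, and no independent data bear on what lies behind it.

On these data alone, whether any group at this position can bring the number far under that of compound 2, which stands at 14000 nM, remains open, as does the outcome for an amine, a carboxylic acid, a methoxy group or a longer chain such as butylsulfanyl. The compounds shown also leave open whether the small difference between methylsulfanyl and hydroxy would persist at another ring carbon or with a change to the shared core.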